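The source may hold more compounds than are shown below. What is called first, only, known or untested is meant among the compounds shown, and "the series" means these compounds.

Compound 1 `CCCOC(=O)C1=C(C)NC(=O)NC1c1ccco1` gives 3% in an assay on membranes from HeLa cells for displacement of a labelled ligand from adenosine receptor A3 (Homo sapiens), read by scintillation counting, with a stated time of 180 min, tested at 1 uM; a higher number here means more inhibition at the concentration tested (going by the name of the read-out), a lower number less inhibition. Compound 2 `CC1=C(C(=O)OCc2ccccc2)C(c2ccco2)NC(=O)N1` gives 3% in this assay, and the step of no change at the digits printed from compound 1 to compound 2 (within the scatter) is the only one measured so far. Compound 2 thus stands level with compound 1 on the numbers in hand, both values lying at the low end of the read-out. The next compound, compound 3 `CC1=C(C(=O)OCc2ccccc2)C(c2ccsc2)NC(=O)N1`, differs from compound 2 by thiophen-3-yl in place of furan-2-yl on a saturated ring carbon. For the measured compounds named here, the single measured step concerned the ester side of the shared core and not the group on the saturated ring carbon, so no measured step bears directly on this change; the only guide is that both measured compounds sit low in this assay. Compound 3 is therefore expected to stay near compound 2, with a step of a number 1 percentage points higher from compound 2 to compound 3 (within the scatter) that is not expected to go beyond the scatter. The estimate for compound 3 in this assay is 4%, within 0% to 15%.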

Compound 3, a percentage reported as inhibition, at one concentration (the size of the read-out at that concentration, not a potency): 25%
Compound 3: middle estimate off by 21 percentage points, on the low side; the whole stated range lies below it.
By their numbers in this assay, from the lowest: compounds 1 and 2 (each within the scatter of the next); then compound 3.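

Within this assay this position responds to change: thiophen-3-yl in place of furan-2-yl on the saturated ring carbon gives a number 22 percentage points higher from compound 2 to compound 3 (beyond the scatter) and lifts the read-out clear of the low level of the earlier compounds. The only earlier step, on the ester side of the shared core, stayed within the scatter, so this is the first single change shown to move the read-out beyond it. The two groups match in heavy atoms, ring size and counted donors and acceptors, differing in oxygen against sulfur and in the attachment shown in their names, and nothing available accounts for the rise.

Going by these compounds, whether the rise follows the sulfur or the point of attachment stays open, and a thiophen-2-yl or furan-3-yl group on this carbon would separate the two. Also open, on these data alone, is what a phenyl ring here would give, and whether the rise would persist with the ester of compound 1.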